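The source may report more compounds than this note shows. Statements on the series, on what has been measured and on what is new or still open speak of the compounds shown alone.

Compound 3 `O=C(/C=C/c1ccccc1)Nc1nnc(-c2ccccc2)[nH]1` gives 1570000 nM in an ADME assay on Vero cells (Chlorocebus sabaeus) for cytotoxicity, read by MTT assay, with a stated time of 72 h (a lower number here means that less compound is tolerated, a higher number that more compound is tolerated), which places it second highest of the three numbers at hand, with compound 2 nearest and compound 1 furthest. Compound 2 `O=C(/C=C/c1ccc(OC(F)(F)F)cc1)Nc1nnc(-c2ccccc2)[nH]1` gives 1560000 nM in this assay, and compound 1 `Nc1ccc(/C=C/C(=O)Nc2nnc(-c3ccccc3)[nH]2)cc1` gives 1910000 nM. The three measured compounds share one core and differ only in the group on one aromatic carbon of the six-membered carbon ring: the steps of a 1.2-fold lower number from compound 1 to compound 2 (0.09 log units; within the scatter), a 1.2-fold lower number from compound 1 to compound 3 (0.09 log units; within the scatter) and a 1.0-fold higher number from compound 2 to compound 3 (0.00 log units; within the scatter) all stay within the scatter, so an amino group, a trifluoromethoxy group and a plain hydrogen there are not told apart by this assay. Compound 4 `C=C(C)COc1ccc(/C=C/C(=O)Nc2nnc(-c3ccccc3)[nH]2)cc1` is reached from compound 3 by the change ((2-methylprop-2-en-1-yl)oxy in place of hydrogen on an aromatic carbon). Going by the values given here, the steps that bear on this are the same three, and since a 1.0-fold higher number from compound 2 to compound 3 (0.00 log units; within the scatter) and a 1.2-fold lower number from compound 1 to compound 3 (0.09 log units; within the scatter) stayed within the scatter, a further substituent at that place is expected to move the number by no more than the scatter in either direction. Compound 4 is therefore expected to give about 1500000 nM in this assay, within a range from 800000 nM to 3000000 nM, which means an expected step of a 1.0-fold lower number from compound 3 to compound 4 (0.02 log units; within the scatter).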

Compound 4, half-maximal cytotoxic concentration: 1420000 nM
Beside the measured number, compound 4's estimate is 1.1-fold (0.02 log units) above it; measured number inside the range.
By their numbers in this assay, from the lowest: compounds 4, 2, 3 and 1 (each within the scatter of the next).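

Compound 4 carries at this aromatic carbon, para to a large group, a (2-methylprop-2-en-1-yl)oxy group, the first substituent here with a double bond outside aromatic rings, and in this assay its steps stay within the scatter (first a 1.1-fold lower number from compound 3 to compound 4 (0.04 log units; within the scatter), then a 1.1-fold lower number from compound 2 to compound 4 (0.04 log units; within the scatter), and last a 1.3-fold lower number from compound 1 to compound 4 (0.13 log units; within the scatter)). The step from compound 2 also shows that 2-methylprop-2-en-1-yl in place of trifluoromethyl on the oxygen is not told apart by this assay. The four compounds thus give no sign that the group at this place matters for the number.

Going by these compounds, whether a carboxylic acid, a tertiary amine or a longer chain at this place would leave the scatter stays open, as does any change elsewhere on the shared core. Nothing at hand speaks to why the number holds across these groups.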